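This account rests on a few compounds, and the source may have more. Where it says the series, first, only, none or still open, it means among the compounds named here.

Measured so far in a functional assay on HepG2 cells (Homo sapiens) for cytotoxicity, read by MTT assay, with a stated time of 24 h; a lower number here means a stronger inhibitor, a higher number a weaker inhibitor:
compound 1 `O=C1/C(=C/c2cccnc2)CN(S(=O)(=O)c2ccc(F)cc2)C/C1=C\c1ccccc1F` — 15600 nM
compound 2 `O=C1/C(=C/c2cccnc2)CN(S(=O)(=O)c2ccc(Cl)cc2)C/C1=C\c1ccccc1F` — 12400 nM
compound 3 `CC(=O)Nc1ccc(S(=O)(=O)N2C/C(=C\c3cccnc3)C(=O)/C(=C/c3ccccc3F)C2)cc1` — 4560 nM

Compound 3 stands at the lowest number of the three. The steps that reach it are a 3.4-fold lower number from compound 1 to compound 3 (0.53 log units; beyond the scatter) and a 2.7-fold lower number from compound 2 to compound 3 (0.43 log units; beyond the scatter), both beyond the scatter, whereas a 1.3-fold lower number from compound 1 to compound 2 (0.10 log units; within the scatter) stays within it. All three of these measured changes sit on the aryl of the sulfonyl group; none of them touches the other end of the shared core.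

Compound 4 `CC(=O)Nc1ccc(S(=O)(=O)N2C/C(=C\c3ccncc3)C(=O)/C(=C/c3ccccc3F)C2)cc1` differs from compound 3 only at that other end: pyridin-4-yl in place of pyridin-3-yl on a double-bonded chain carbon bound to a double-bonded ring carbon. Going by the values given here, no measured step bears on this change. Among the compounds with values here, every step so far alters the group on the sulfonyl, and nothing shows how the exchange of pyridin-3-yl for pyridin-4-yl plays out in this assay. With nothing to lean on, the expectation is a step of no size beyond the scatter, in neither direction, and the estimate for compound 4 is therefore taken from compound 3 with a widened range to cover the unknown. Compound 4 is expected to give 4600 nM in this assay, within 1800 nM to 12000 nM, which means an expected step of a 1.0-fold higher number from compound 3 to compound 4 (0.00 log units; within the scatter).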

Compound 4, half-maximal inhibitory concentration: 11700 nM
Estimate against measurement, compound 4: 2.5-fold (0.41 log units) below; low and high end bracket the measured number.
By their numbers in this assay, from the lowest: compound 3; then compounds 4, 2 and 1 (each within the scatter of the next).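

In this assay, this position on the shared core proves able to move the number, as a 2.6-fold higher number from compound 3 to compound 4 (0.41 log units; beyond the scatter) comes from pyridin-4-yl in place of pyridin-3-yl on a double-bonded chain carbon bound to a double-bonded ring carbon. The two groups have the same atoms joined differently and the same counts of hydrogen-bond donors and acceptors, so those counts do not separate them, and the change in this assay follows the way the atoms are joined within the group. No measurement is available to explain the step.

The compounds shown leave open how a pyridin-2-yl or a plain phenyl group at this place would compare with pyridin-3-yl and pyridin-4-yl, and so whether pyridin-3-yl is favoured or pyridin-4-yl is disfavoured. They also leave open whether the step carries over when the acetamido group of compound 3 and compound 4 is replaced by the fluoro of compound 1 or the chloro of compound 2, or whether it holds only with acetamido on the sulfonyl aryl group.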